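Removing one chloro from a trichloropyridyl ether

The source may report more compounds than this note shows. Statements on the series, on what has been measured and on what is new or still open speak of the compounds shown alone.

Compound 1 `Clc1cc(OC[C@@H]2C[C@H]3C[C@H]3N2)c(Cl)nc1Cl` and compound 2 `Cc1ccc(OC[C@@H]2C[C@H]3C[C@H]3N2C)cn1` share the same bicyclic amine core carrying an oxymethyl-linked pyridine. In an assay on CHO-K1 cells for displacement of a labelled ligand from Neuronal acetylcholine receptor; alpha4/beta2 (Homo sapiens), read by scintillation counting (on this read-out lower numbers stand for stronger inhibition and higher numbers for weaker inhibition), compound 1 gives 265 nM, the higher of the two numbers recorded, while compound 2 gives 20 nM, a lower number whose gap to compound 1 lies beyond the usual scatter. Compound 3 `Clc1cc(OC[C@@H]2C[C@H]3C[C@H]3N2)cnc1Cl` has not yet been measured; it differs from compound 1 in a single place, (hydrogen in place of chloro on an aromatic carbon), the chloro that is lost being the one next to the ring nitrogen and ortho to the ether-bearing group of 8 heavy atoms. Because compound 1 stands at 265 nM, the higher end of what is known here, there is room for a lower number, and the estimated step from compound 1 to compound 3, a 7.6-fold lower number from compound 1 to compound 3 (0.88 log units; beyond the scatter), is expected to fall beyond the scatter toward stronger inhibition. Compound 3 is thus expected to give about 35 nM in this assay, within a range from 6 nM to 200 nM.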

Compound 3, inhibition constant: 149 nM
Beside the measured number, compound 3's estimate is 4.3-fold (0.63 log units) below it; the measured number falls inside the stated range.
By their numbers in this assay, from the lowest: compound 2; then compounds 3 and 1 (each within the scatter of the next).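

In this assay, hydrogen in place of chloro next to the ring nitrogen amounts to a 1.8-fold lower number from compound 1 to compound 3 (0.25 log units; within the scatter). This single exchange therefore shows that, on this trichloropyridyl ether, the chloro at this place can be lost without a change in the number that stands beyond the scatter, something the unmatched pair of earlier compounds could not show. No evidence is available here to explain why this step is so small.

On these data alone, whether a methyl, a methoxy group or an amine at this same place would keep the number within the scatter remains open. Also open is what each remaining chloro, meta and para to this place, contributes, as no step among the compounds shown touches either of them.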